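The compounds below may be only part of what the source reports. "The series", "measured", "known", "first", "only" and "open" are said of these compounds alone.

Among the compounds with values here, in an assay for inhibition of Nicotinamide phosphoribosyltransferase (Mus musculus), read by fluorescence, with a stated time of 1 h, in the presence of a further agent that is not named here (on this read-out higher numbers stand for weaker inhibition and lower numbers for stronger inhibition), compound 3 `O=C(NCCCCCCCn1cc(-c2cccnc2)nn1)c1ccccc1-c1cccnc1` gives 28.5 nM, the only number among the three values shown. Compound 1 `O=C(O)c1cccc(-c2ccccc2C(=O)NCCCCCCCn2cc(-c3cccnc3)nn2)c1` stands at the limit of > 500 nM in this assay. Compound 2 `O=C(O)c1ccc(-c2ccccc2C(=O)NCCCCCCCn2cc(-c3cccnc3)nn2)cc1` likewise sits at the limit of > 500 nM in this assay. The step of an at least 17-fold lower number from compound 1 to compound 3 (1.24 log units; beyond the scatter) and the step of an at least 17-fold lower number from compound 2 to compound 3 (1.24 log units; beyond the scatter) both show that exchanging a carboxyphenyl for the pyridin-3-yl brings a large gain, whereas the step that the two limits leave unreadable from compound 1 to compound 2 is not readable.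

Compound 4 `CN(C)Cc1cn(-c2ccccc2C(=O)NCCCCCCCn2cc(-c3cccnc3)nn2)nn1` differs from compound 3 by 4-((dimethylamino)methyl)-1H-1,2,3-triazol-1-yl in place of pyridin-3-yl on an aromatic carbon. Within the data shown here, no measured step replaces the pyridin-3-yl with a triazolyl; the two readable steps only show that the pyridin-3-yl outperforms either carboxyphenyl by a wide margin. This account therefore expects the exchange to cost activity in this assay, with an estimated step of an 8.8-fold higher number from compound 3 to compound 4 (0.94 log units; beyond the scatter). Compound 4 is estimated at 250 nM in this assay, expected to fall between 50 nM and 1200 nM.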

Compound 4, half-maximal inhibitory concentration: 42.4 nM
For compound 4 the middle estimate is 5.9-fold (0.77 log units) above the measured one; measured number below the stated range.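

At this aromatic carbon, ortho to a large group, the activity in this assay does not depend on a six-membered aromatic ring: the 4-((dimethylamino)methyl)-1H-1,2,3-triazol-1-yl group, a five-membered aromatic ring with 3 hetero atoms, replaces pyridin-3-yl with a 1.5-fold higher number from compound 3 to compound 4 (0.17 log units; within the scatter). The advantage over the carboxyphenyl groups is therefore not unique to pyridin-3-yl, as the triazolyl group also gives an at least 11-fold lower number from compound 2 to compound 4 (1.07 log units; beyond the scatter) and an at least 11-fold lower number from compound 1 to compound 4 (1.07 log units; beyond the scatter). The values for compound 1 and compound 2 are limits, not numbers, so the true size of both steps remains unknown: the limit of > 500 nM in this assay, at which 2 of the 4 values shown sit.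

The compounds shown do not separate the contribution of the triazole ring from that of its dimethylaminomethyl group. A triazole carrying a hydroxymethyl group or a carboxylic acid in that place, or an unsubstituted triazole, would address this question.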